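Changing the aryl group on the ring nitrogen

The compounds below may be only part of what the source reports. "The series", "measured", "known", "first", "only" and "open" are said of these compounds alone.

Of the compounds shown here, three that share one core have been tested in a functional assay on HepG2 cells (Homo sapiens) for antiproliferative activity, read by MTT assay, with a stated time of 48 h; a higher number here means a weaker inhibitor, a lower number a stronger inhibitor. Compound 1 `Cc1cccc(-n2nncc2CN2C(=O)C3(C(C#N)=C(N)Oc4c(N)cc5nc6ccccc6nc5c43)c3ccccc32)c1` carries a 3-methylphenyl group on an aromatic nitrogen; in this assay compound 1 reaches only a limit, > 50000 nM. Compound 2 `N#CC1=C(N)Oc2c(N)cc3nc4ccccc4nc3c2C12C(=O)N(Cc1cnnn1-c1ccc([N+](=O)[O-])cc1)c1ccccc12` has a 4-nitrophenyl group in the same place, and in this assay compound 2 likewise gives a limit, > 50000 nM. Compound 3 `N#CC1=C(N)Oc2c(N)cc3nc4ccccc4nc3c2C12C(=O)N(Cc1cnnn1-c1cc(Cl)ccc1Cl)c1ccccc12` bears a 2,5-dichlorophenyl group and is the only one of the three with a measured number, 33100 nM in this assay. The steps from the two limits to it are an at least 1.5-fold lower number from compound 1 to compound 3 (0.17 log units; that floor lies within the scatter) and an at least 1.5-fold lower number from compound 2 to compound 3 (0.17 log units; that floor lies within the scatter); as two of the three values sit at the limit of > 50000 nM in this assay, at which 2 of the 3 values shown sit, the size of these steps cannot be fixed any further.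

Compound 4 `N#CC1=C(N)Oc2c(N)cc3nc4ccccc4nc3c2C12C(=O)N(Cc1cnnn1-c1ccc(F)c(Cl)c1)c1ccccc12` is not yet measured. It differs from compound 3 in one place: 3-chloro-4-fluorophenyl in place of 2,5-dichlorophenyl on an aromatic nitrogen. Among the measured compounds shown here, no measured step involves a 3-chloro-4-fluorophenyl group, and the two steps that lead to compound 3 are small at their floor. The step from compound 3 to compound 4 is expected to be small, about a 1.4-fold higher number from compound 3 to compound 4 (0.13 log units; within the scatter), possibly drifting back toward the limit. Compound 4 is expected to give about 45000 nM in this assay, within a range from 15000 nM to 150000 nM.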

Compound 4, half-maximal inhibitory concentration: > 50000 nM
Compound 4: no number, only a limit; the forecaster's own chance of this, stated with the estimate: 40%; middle value at least 1.1-fold (0.04 log units) from the limit.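

Replacing the 2,5-dichlorophenyl group with the 3-chloro-4-fluorophenyl group keeps the count of 8 heavy atoms and the single aromatic ring of carbon, yet gives an at least 1.5-fold higher number from compound 3 to compound 4 (0.17 log units; that floor lies within the scatter). Among the compounds shown here, a halogen-bearing phenyl group on this aromatic nitrogen therefore does not in itself secure a measured number in this assay, and compound 3 remains the only one of the four compounds with a value that is not a limit. The steps from compound 1 and from compound 2 to compound 4 cannot be read, and most of the set now rests at one limit: the limit of > 50000 nM in this assay, at which 3 of the 4 values shown sit.

For the compounds shown here, the one readable step is only a floor, so its true size remains open, as does whether it goes beyond the scatter or which of the changes in halogen pattern matters. The compounds shown also leave open what a plain phenyl, a benzyl group, or a phenyl carrying an amine or a carboxylic acid would give on this nitrogen, and whether any such group would give a clearly lower number than compound 3, at 33100 nM.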